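A Hydroxymethyl Group Added to Compound 2

A few compounds are considered here, and "the series" means these few. Any claim that something is new, unique, unknown or untested is made for them only; others in the source may bear on it.

Going by the values given here, in a physicochemical assay for solubility, measured as kinetic solubility (on this read-out lower numbers stand for lower solubility and higher numbers for higher solubility), two compounds have numbers so far. Compound 1 (`CS(=O)(=O)c1cccc([C@H](CO)NC(=O)c2cc(C(F)(F)F)ccc2Oc2ccccc2)c1`) gives 11000 nM, and compound 2 (`CS(=O)(=O)c1cccc(CNC(=O)c2cc(S(F)(F)(F)(F)F)ccc2Oc2ccccc2)c1`) gives 7000 nM. These two values lie within the usual scatter of each other, so compound 2 stands level with compound 1 on the numbers at hand. Among the compounds with values here, the two compounds differ in more than one place, so they offer no clean single step.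

Compound 3 (`CS(=O)(=O)c1cccc([C@H](CO)NC(=O)c2cc(S(F)(F)(F)(F)F)ccc2Oc2ccccc2)c1`) has not yet been measured. It differs from compound 2 in one place: hydroxymethyl in place of hydrogen on a saturated chain carbon bound to an amide-type nitrogen and an aromatic carbon, with hydroxymethyl in place of hydrogen on a saturated chain carbon bound to an amide-type nitrogen and an aromatic carbon. Within the data shown here, compound 1 carries hydroxymethyl on that same kind of carbon and gives 11000 nM, so the only guide available points to no large shift in this assay. The expected change, a 1.3-fold higher number from compound 2 to compound 3 (0.11 log units; within the scatter), is not expected to go beyond the scatter in either direction. For compound 3 the estimated value is 9000 nM, with an expected range of 3500 nM to 22000 nM.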

Compound 3, solubility: 121000 nM
Compound 3: middle estimate off by 13-fold (1.13 log units), on the low side; measured number outside the range, above it.
By their numbers in this assay, from the lowest: compounds 2 and 1 (each within the scatter of the next); then compound 3.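

In this assay, going by these compounds alone, hydroxymethyl in place of hydrogen on a saturated chain carbon bound to an amide-type nitrogen and an aromatic carbon gives a 17-fold higher number from compound 2 to compound 3 (1.24 log units; beyond the scatter) as the first clean single-place step at this position, and that step is large. A second large step, an 11-fold higher number from compound 1 to compound 3 (1.04 log units; beyond the scatter), comes with the group of 6 heavy atoms (5 fluorine, 1 sulfur; no ring) in place of the group of 4 heavy atoms (1 carbon, 3 fluorine; no ring) on an aromatic carbon, so the hydroxymethyl alone does not set the number, and neither does the group on the aromatic carbon: compound 1 and compound 2 each carry only one of these features and stay within the scatter of each other, while compound 3 carries both and stands clear of them. Nothing at hand gives any measured property that bears on why the two changes act this way together.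

On these data alone, whether a methyl, an aminomethyl or a carboxylic acid on that same chain carbon would give a step of this size remains open. So does the size of the hydroxymethyl step with trifluoromethyl on the aromatic carbon, as the compounds shown offer no partner for compound 1 that carries hydrogen on the chain carbon.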